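Working notes: cyano in place of methoxy

The source may report more compounds than this note shows. Statements on the series, on what has been measured and on what is new or still open speak of the compounds shown alone.

Measured in a toxicity assay on MT4 cells (Homo sapiens) for cytotoxicity, read by MTT assay; on this read-out higher numbers stand for lower toxicity in this test and lower numbers for higher toxicity in this test:
- compound 1 `Cc1cc(-c2ccccc2)cc(C)c1Oc1cc(N)nc(Nc2ccc(C#N)cc2)n1`: 25600 nM
- compound 2 `Cc1ccccc1-c1cc(C)c(Oc2cc(N)nc(Nc3ccc(C#N)cc3)n2)c(C)c1`: 25600 nM
- compound 3 `COc1ccc(-c2cc(C)c(Oc3cc(N)nc(Nc4ccc(C#N)cc4)n3)c(C)c2)cc1`: 10700 nM

Compound 3 holds the lowest number of the three, at 10700 nM. The next structure is compound 4 `Cc1cc(-c2ccc(C#N)cc2)cc(C)c1Oc1cc(N)nc(Nc2ccc(C#N)cc2)n1`, which carries cyano in place of methoxy on an aromatic carbon, para to a large group: cyano in place of methoxy on an aromatic carbon.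

Among the compounds with values here, two measured steps bear on this change. Adding methoxy gave a 2.4-fold lower number from compound 1 to compound 3 (0.38 log units; beyond the scatter), and exchanging the aryl group gave a 2.4-fold lower number from compound 2 to compound 3 (0.38 log units; beyond the scatter). Adding methyl gave no change at the digits printed from compound 1 to compound 2 (within the scatter). Within the data shown here, no measured compound has cyano at this place, so its own contribution is unknown. Compound 4 loses the methoxy present in compound 3, so some return toward the number of compound 1 at 25600 nM is expected, though probably only part of the way.

The expected result in this assay is a small upward move, a 1.5-fold higher number from compound 3 to compound 4 (0.17 log units; within the scatter). For compound 4 the estimated value is 16000 nM, with an expected range from 7000 nM to 32000 nM.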

Compound 4, half-maximal cytotoxic concentration: 18100 nM
Estimate against measurement, compound 4: 1.1-fold (0.05 log units) below; low and high end bracket the measured number.
By their numbers in this assay, from the lowest: compounds 3, 4, 1 and 2 (each within the scatter of the next, the first and the last beyond it).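

Cyano in place of methoxy on this aromatic carbon, para to a large group, gives in this assay a 1.7-fold higher number from compound 3 to compound 4 (0.23 log units; within the scatter) and so cannot be told apart from methoxy at the resolution of this test. Cyano in place of hydrogen gives a 1.4-fold lower number from compound 1 to compound 4 (0.15 log units; within the scatter) and 4-cyanophenyl in place of 2-methylphenyl gives a 1.4-fold lower number from compound 2 to compound 4 (0.15 log units; within the scatter), so the nitrile also stays within the scatter of compound 1 and compound 2, although compound 3 lies beyond it from both. Nothing at hand explains these numbers.

From the compounds shown here alone, whether an amine or a carboxylic acid at this aromatic carbon would give a step beyond the scatter remains open. So does the effect of a longer chain there, such as butoxy, on this read-out.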